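The source may hold more compounds than are shown below. What is called first, only, known or untested is meant among the compounds shown, and "the series" means these compounds.

Compound 1, `COc1ccc(C(=O)/C=C/c2ccc(F)cc2)c2c1C=CC(C)(C)O2`, belongs to a small set tested in a functional assay on K562 cells (Homo sapiens) for antiproliferative activity, read by MTT assay, with a stated time of 24 h; a higher number here means a weaker inhibitor, a lower number a stronger inhibitor. In this assay compound 1 gives only a limit, > 10000 nM, not a number. The companions help place it. Compound 2, `COc1ccc(C(=O)/C=C/c2ccc(N(c3ccccc3)c3ccccc3)cc2)c2c1C=CC(C)(C)O2`, also reaches only a limit in this assay, > 10000 nM. Going by the values given here, compound 3, `COc1ccc(C(=O)/C=C/c2ccc3ccccc3n2)c2c1C=CC(C)(C)O2`, is the one member that returns a number, 3020 nM in this assay. So compound 1 stands at the weak end of what is shown, sitting at the limit of > 10000 nM in this assay, at which 2 of the 3 values shown sit, and no pair among these three differs in only one place, so no measured step is available to lean on.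

Compound 4, `COc1ccc(C(=O)/C=C/c2ccc(C(F)(F)F)cc2)c2c1C=CC(C)(C)O2`, is the next one to be tested. Against compound 1 its change is trifluoromethyl in place of fluoro on an aromatic carbon, para to a large group, with no change in ring count, donors, acceptors or charge. With compound 1 already at a limit, no step beyond the scatter is expected in either direction; the step this implies, a step that the limit leaves unreadable from compound 1 to compound 4, is expected to be essentially none. Compound 4 is therefore estimated at 15000 nM in this assay, within a range of 5000 nM to 50000 nM, and it is expected most likely to return another limit rather than a number.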

Compound 4, half-maximal inhibitory concentration: > 10000 nM
Compound 4 gave a limit, no number; the forecaster's own chance of this, stated with the estimate: 70%; the middle value is on the limit's open side.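

In this assay compound 1 and compound 4 both return only limits, so no step can be read between them, and the swap of fluoro for trifluoromethyl has no measurable size here. Compound 4 joins the cluster at that limit: the limit of > 10000 nM in this assay, at which 3 of the 4 values shown sit. The compounds shown leave open how far past that limit each of these three lies.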